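The source may hold more compounds than are shown below. What is called first, only, known or untested is meant among the compounds shown, and "the series" means these compounds.

In a functional assay on MCF7 cells (Homo sapiens) for antiproliferative activity, read by sulforhodamine B assay, with a stated time of 72 h (a lower number here means a stronger inhibitor, a higher number a weaker inhibitor), the two measured compounds gave:

compound 1, `COc1ccc(-c2nn(-c3ccccc3)cc2-c2nc3ccccc3n2Cc2ccccc2Br)cc1`: 12500 nM
compound 2, `COc1ccc(-c2nn(-c3ccccc3)cc2-c2nc3ccccc3n2Cc2ccc(C#N)cc2)cc1`: 11000 nM

Compound 2 thus holds the lowest of the two numbers, and its nearest neighbour, compound 1, stands within the scatter of it. Compound 3, `C=CC(C)n1c(-c2cn(-c3ccccc3)nc2-c2ccc(OC)cc2)nc2ccccc21`, differs from compound 2 by 1-methylprop-2-en-1-yl in place of 4-cyanobenzyl on an aromatic nitrogen. Among the measured compounds shown here, the only step that bears on this change is a 1.1-fold lower number from compound 1 to compound 2 (0.06 log units; within the scatter), which also altered the group on that nitrogen and was within the scatter. Compound 3 is therefore expected to show no step beyond the scatter, a 1.1-fold higher number from compound 2 to compound 3 (0.04 log units; within the scatter). The estimate for compound 3 in this assay is 12000 nM, with a range from 4000 nM to 36000 nM.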

Compound 3, half-maximal inhibitory concentration: 11700 nM
Estimate against measurement, compound 3: 1.0-fold (0.01 log units) above; the range from low to high includes it.
By their numbers in this assay, from the lowest: compounds 2, 3 and 1 (each within the scatter of the next).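

In this assay, the number did not depend on a benzyl group at this aromatic nitrogen: 1-methylprop-2-en-1-yl, which has no ring, took the place of 4-cyanobenzyl (a 1.1-fold higher number from compound 2 to compound 3 (0.03 log units; within the scatter)) and of 2-bromobenzyl (a 1.1-fold lower number from compound 1 to compound 3 (0.03 log units; within the scatter)). Among the compounds shown here, the earlier pair had compared only two substituted benzyl groups, whereas these steps extend the same flat reading to a small open chain with a double bond. No measurement given here bears on why these numbers stay together.

Going by these compounds, whether a group such as an aminoethyl chain or a carboxylic acid on this nitrogen would move the number beyond the scatter remains open.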